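Cytotoxicity of benzophenone-bearing benzimidazoles: the step to compound 4

The source may hold more compounds than are shown below. What is called first, only, known or untested is meant among the compounds shown, and "the series" means these compounds.

Compound 1, `O=C(NCCO)Nc1nc2cc(C(=O)c3ccccc3)ccc2[nH]1`: > 30000 nM
Compound 2, `NCCCC(=O)Nc1nc2ccc(C(=O)c3ccccc3)cc2[nH]1`: > 30000 nM
Compound 3, `CN1CCC(Cn2c(N)nc3ccc(C(=O)c4ccccc4)cc32)CC1`: > 30000 nM

In an ADME assay on CRL8155 cells (Homo sapiens) for cytotoxicity, read by resazurin assay, with a stated time of 72 h (a lower number here means that less compound is needed, a higher number that more compound is needed for the effect), compound 1 reaches only a limit, not a number. The same holds for compound 2 in this assay. Compound 3, in this assay, likewise gives only a limit, and so it stands together with the other two at the limit of > 30000 nM in this assay, at which 3 of the 3 values shown sit.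

Compound 4, `Nc1nc2ccc(C(=O)c3ccccc3)cc2n1C[C@@H]1CCCN1`, differs from compound 3 in one place: pyrrolidin-2-yl in place of 1-methylpiperidin-4-yl on a saturated chain carbon bound to an aromatic nitrogen. Among the compounds with values here, since every value shown is a limit, no measured step exists to guide the size of the change; the expectation is no shift beyond the usual scatter, so a number no higher from compound 3 to compound 4 (the limit leaves the size open) is estimated. Compound 4 is therefore expected to give about 30000 nM in this assay, between 10000 nM and 100000 nM, most likely again reported as a limit.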

Compound 4, half-maximal effective concentration: > 30000 nM
Compound 4: no number, only a limit (the forecaster's own chance of this, stated with the estimate: 85%); the middle value sits exactly at the limit.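

Within the data shown here, compound 3 and compound 4 both give only a limit in this assay, so no step between them can be read. The compounds shown leave open at what concentration any of them would reach the half-maximal effect.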